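Benzyloxy to hydroxy on compound 3

A few compounds are considered here, and "the series" means these few. Any claim that something is new, unique, unknown or untested is made for them only; others in the source may bear on it.

Values in a functional assay on HepG2 cells (Homo sapiens) for cytotoxicity, read by spectrophotometry, with a stated time of 72 h; a lower number here means a stronger inhibitor, a higher number a weaker inhibitor:
- Compound 1 `COc1cc(-n2c(-c3ccc([N+](=O)[O-])cc3)cccc2=O)cc(OC)c1OC` gives < 10 nM (a limit of the assay, not a number)
- Compound 2 `COc1cc(-n2c(-c3ccncc3)cccc2=O)cc(OC)c1OC` gives 1780 nM
- Compound 3 `COc1ccc(-n2c(-c3cc(OC)c(OC)c(OC)c3)cccc2=O)cc1OCc1ccccc1` gives 3040 nM

Compound 3 lies within the scatter of compound 2, and the two sit at the upper end of the numbers shown. Compound 4 `COc1ccc(-n2c(-c3cc(OC)c(OC)c(OC)c3)cccc2=O)cc1O` carries one change (hydrogen in place of benzyl on an oxygen on an aromatic ring), benzyloxy to hydroxy. Going by the values given here, no measured step touches this place. Among the compounds with values here, the only step, an at least 170-fold higher number from compound 1 to compound 2 (2.25 log units; beyond the scatter), lies elsewhere on the shared core, yet it shows that one exchange can move the number far in this assay here. With compound 3 at 3040 nM, a large step to a lower number is expected, on thin evidence. The expected change is a 10-fold lower number from compound 3 to compound 4 (1.01 log units; beyond the scatter) overall. For compound 4 the estimate is 300 nM, with an expected range from 20 nM to 3000 nM in all.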

Compound 4, half-maximal inhibitory concentration: 1220 nM
The estimate for compound 4 lay 4.1-fold (0.61 log units) below the measured number, within the range that was stated.
By their numbers in this assay, from the lowest: compounds 4, 2 and 3 (each within the scatter of the next, the first and the last beyond it). At a limit, below all of these: compound 1.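

In this assay the oxygen on the aromatic ring now has a read step of its own: hydrogen in place of benzyl gives a 2.5-fold lower number from compound 3 to compound 4 (0.40 log units; beyond the scatter) and the number moves only modestly. The whole benzyl can therefore leave this oxygen without a loss in this assay, and the step is much smaller than an at least 170-fold higher number from compound 1 to compound 2 (2.25 log units; beyond the scatter) at the other place on the shared core. Nothing at hand gives a reason for the step.

On these data alone, whether an amine or a carboxylic acid carried on a longer chain at this oxygen would move the number further stays open. So does whether the same exchange would act alike with the 4-nitrophenyl of compound 1.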